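The source may report more compounds than this note shows. Statements on the series, on what has been measured and on what is new or still open speak of the compounds shown alone.

Three compounds have so far been measured in an ADME assay on HepG2 cells (Homo sapiens) for cytotoxicity, read by CellTiter-Glo and ATP content, with a stated time of 72 h; a lower number here means that less compound is needed, a higher number that more compound is needed for the effect:

- compound 1, `CC(C)N(C(=O)CNC(=O)c1ccc(S(C)(=O)=O)c([N+](=O)[O-])c1)C(C)C`, gives > 27000 nM
- compound 2, `CN(Cc1ccccc1)C(=O)CNC(=O)c1ccc(S(C)(=O)=O)c([N+](=O)[O-])c1`, gives > 27000 nM
- compound 3, `CS(=O)(=O)c1ccc(C(=O)NCC(=O)N2CCN(c3ccccc3F)CC2)cc1[N+](=O)[O-]`, gives > 27000 nM

Compound 3 stands at a limit, not at a number: its value of > 27000 nM only tells that the assay could not reach a half-maximal effect within the tested range. The two other values are limits as well, so all three measured compounds sit at the limit of > 27000 nM in this assay, at which 3 of the 3 values shown sit. Within the data shown here, this is why the one step between measured compounds that differ in a single place, a step that the two limits leave unreadable from compound 1 to compound 2, cannot be read: its two ends are both limits, and its size stays hidden. That step swapped one group on the carbonyl carbon for another and left the compound at the limit.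

Compound 4, `CN1CCN(C(=O)CNC(=O)c2ccc(S(C)(=O)=O)c([N+](=O)[O-])c2)CC1`, is the next compound to be measured. It differs from compound 3 by methyl in place of 2-fluorophenyl on an amine nitrogen in a ring. Among the measured compounds shown here, no measured step touches this part of the shared core, so nothing in the data points to a change in either direction. For the measured compounds named here, the only guidance is that every variation tested so far at the far end of the molecule has stayed at the limit. The step that the limit leaves unreadable from compound 3 to compound 4 is therefore expected to be none beyond the scatter, and compound 4 is estimated at 40000 nM, within a range from 18000 nM to 120000 nM, with the assay most likely reporting a limit again.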

Compound 4, half-maximal effective concentration: > 27000 nM
Compound 4 ended at the assay's limit (the forecaster's own chance of this, stated with the estimate: 85%); the middle value does not contradict the limit.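

In this assay compound 4 gives > 27000 nM, which is a limit and not a number. Among these compounds, no step from compound 1, compound 2 or compound 3 to compound 4 can be read, because both ends of each step are limits: the limit of > 27000 nM in this assay, at which 4 of the 4 values shown sit. The compounds shown leave open how far apart their true values lie.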